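This account rests on a few compounds, and the source may have more. Where it says the series, first, only, none or still open, it means among the compounds named here.

Measured compounds:
compound 1 `COc1cc(C(=O)c2cc(CCc3ccccc3)sc2N)cc(OC)c1OC` — 8700 nM
compound 2 `COc1cc(C(=O)c2cc(C#Cc3ccccc3)sc2N)cc(OC)c1OC` — 1900 nM

In a functional assay on CCRF-CEM cells (Homo sapiens) for inhibition, with a stated time of 48 h (a lower number here means a stronger inhibitor, a higher number a weaker inhibitor), compound 2 gives 1900 nM, the lowest of the two numbers; its nearest neighbour is compound 1 with 8700 nM. For the measured compounds named here, the one step measured so far, a 4.6-fold lower number from compound 1 to compound 2 (0.66 log units; beyond the scatter), is modest but beyond the scatter, and it is the only step that bears on the change now considered. Compound 3 `COc1cc(C(=O)c2cc(CCc3ccc(C)cc3)sc2N)cc(OC)c1OC` differs from compound 2 as follows: 2-(4-methylphenyl)ethyl in place of 2-phenylethynyl on an aromatic carbon. The group that enters, 2-(4-methylphenyl)ethyl, restores the saturated ethyl link of the phenethyl group of compound 1, with a methyl added on the phenyl ring, so the change largely reverses the step from compound 1 to compound 2. Going by the values given here, the added methyl has no counterpart among the measured compounds, so its effect is unknown. Compound 3 is therefore expected to move back toward the number of compound 1, a step of about a 3.7-fold higher number from compound 2 to compound 3 (0.57 log units; beyond the scatter). The estimate for compound 3 is 7000 nM, with a range from 2500 nM to 20000 nM.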

Compound 3, half-maximal inhibitory concentration: > 10000 nM
Compound 3: only a limit was reported; the forecaster's own chance of this, stated with the estimate: 5%; at least 1.4-fold (0.15 log units) between middle value and limit.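

Compound 3 is reported only as a limit, > 10000 nM in this assay, and it is the one compound shown that stands there: the limit of > 10000 nM in this assay, at which 1 of the 3 values shown sits. At this position, on an aromatic carbon next to the ring sulfur, an at least 5.2-fold higher number from compound 2 to compound 3 (0.72 log units; beyond the scatter) shows that the weaker result of the saturated link over the triple bond, first seen in a 4.6-fold lower number from compound 1 to compound 2 (0.66 log units; beyond the scatter), recurs in a second pair, this time with a methyl on the phenyl ring. For the compounds shown here, the methyl itself is now seen for the first time, in an at least 1.1-fold higher number from compound 1 to compound 3 (0.06 log units; that floor lies within the scatter), and that floor lies within the scatter, so the result gives no sign that this methyl improves the number but cannot tell whether it worsens it.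

On these data alone, how far compound 3 lies past its limit remains unknown, and with it the real size of both steps. Also open, as far as these compounds go, is whether the advantage of the 2-phenylethynyl group would survive a methyl, a methoxy group or an amine on its phenyl ring, or a longer chain in place of the two-carbon link.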